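The source may hold more compounds than are shown below. What is called first, only, known or untested is meant among the compounds shown, and "the series" means these compounds.

In a physicochemical assay for solubility, read by HPLC, using the shake flask method, in phosphate buffer, with a stated time of 20 h, at pH 6.5 (on this read-out higher numbers stand for higher solubility and lower numbers for lower solubility), compound 1 `CN1CCN(CC2CCN(c3nccc4[nH]c(-c5ccc(F)c(F)c5)nc34)CC2)CC1` gives 195000 nM. Among the compounds with values here, its only measured neighbour, compound 2 `CN1CCN(C(=O)C2CCN(c3nccc4[nH]c(-c5ccc(F)c(F)c5)nc34)CC2)CC1`, gives 200000 nM, and the two numbers lie within the scatter of each other. Compound 3 `CN1CCN(CC2CCN(c3nccc4[nH]c(-c5ccc(F)c(C(F)(F)F)c5)nc34)CC2)CC1` differs from compound 1 in one place trifluoromethyl in place of fluoro on an aromatic carbon, ortho to a fluoro group and meta to a large group. Within the data shown here, only one measured step is available for comparison: a 1.0-fold higher number from compound 1 to compound 2 (0.01 log units; within the scatter). It puts (4-methylpiperazin-1-yl)carbonyl in place of (4-methylpiperazin-1-yl)methyl on a saturated ring carbon, and its size lies within the scatter. Among the measured compounds shown here, that step sits elsewhere in the molecule, however, and no measured step touches the aromatic ring, so it gives only weak guidance. The data fix no direction for the new change. As a matter of judgement, a small move toward a lower number in this assay is expected, possibly not much beyond the scatter. The expected change is a 1.4-fold lower number from compound 1 to compound 3 (0.14 log units; within the scatter). For compound 3 the estimated value is 140000 nM, with an expected range from 60000 nM to 230000 nM.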

Compound 3, solubility: 165000 nM
Estimate against measurement, compound 3: 1.2-fold (0.07 log units) below; the measured number falls inside the stated range.
By their numbers in this assay, from the lowest: compounds 3, 1 and 2 (each within the scatter of the next).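

In this assay the aromatic ring now has a measured step of its own, with a 1.2-fold lower number from compound 1 to compound 3 (0.07 log units; within the scatter) for trifluoromethyl in place of fluoro, ortho to a fluoro group and meta to a large group. Within the data shown here, this swap of 3,4-difluorophenyl to 4-fluoro-3-(trifluoromethyl)phenyl brings four heavy atoms where one stood, yet the number stays within the scatter at this position, which the earlier compounds could not show. Together with a 1.0-fold higher number from compound 1 to compound 2 (0.01 log units; within the scatter) on a saturated ring carbon, this means that both single changes made to compound 1 stay within the scatter, although the measurements in hand offer no explanation for this result.

On these data alone, what an amine, a carboxylic acid or a longer chain on this aromatic carbon would do to the number remains open, since both groups seen there so far, fluoro and trifluoromethyl, give values within the scatter of each other. As far as these compounds go, it also remains open whether trifluoromethyl in place of fluoro would give a similar step when the (4-methylpiperazin-1-yl)carbonyl group of compound 2 is present.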